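A few compounds are considered here, and "the series" means these few. Any claim that something is new, unique, unknown or untested is made for them only; others in the source may bear on it.

Measured so far in a functional assay on the whole organism for inhibition of sodium-dependent dopamine transporter (Mus musculus); a higher number here means that more compound is needed for the effect, a lower number that less compound is needed:
- compound 1 `CN1Cc2c(N)cccc2C(c2ccc(Cl)cc2)C1`: 1.5 mg/kg
- compound 2 `CCCCNC(=O)Nc1cccc2c1CN(C)CC2c1ccc(Cl)cc1`: about 120 mg/kg
- compound 3 `CCOC(=O)Nc1cccc2c1CN(C)CC2c1ccccc1`: 2.5 mg/kg

Compound 3 stands second highest of the three numbers in this assay. Its nearest neighbour is compound 1, whose number is lower by an amount within the scatter; compound 2 lies far above it, beyond the scatter. Among the compounds with values here, the only single-point step measured so far, an 80-fold higher number from compound 1 to compound 2 (1.90 log units; beyond the scatter), concerns the nitrogen on the aromatic ring and is large.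

Compound 4 `CCOC(=O)Nc1cccc2c1CN(C)CC2c1ccc(Cl)cc1` differs from compound 3 by chloro in place of hydrogen on an aromatic carbon. Within the data shown here, no measured pair isolates this change: compound 1 and compound 2 both already carry the chloro group, and compound 3 is the only compound without it, so the step from compound 1 to compound 2 does not bear on it. The comparison of compound 3 with compound 1 mixes two changes and shows a gap within the scatter, which gives no sign that the chloro group by itself moves the number much.

The expected step of a 1.3-fold lower number from compound 3 to compound 4 (0.10 log units; within the scatter) is therefore small, without a clear direction, and within the scatter. Compound 4 is estimated at 2 mg/kg in this assay, with a range from 0.7 mg/kg to 6 mg/kg.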

Compound 4, dose for half-maximal effect: 21 mg/kg
Compound 4: middle estimate off by 11-fold (1.02 log units), on the low side; measured number above the stated range.
By their numbers in this assay, from the lowest: compounds 1 and 3 (each within the scatter of the next); then compound 4; then compound 2.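

With ethoxycarbonyl on the nitrogen on the aromatic ring, chloro in place of hydrogen, para to a large group, is not a neutral change in this assay: an 8.4-fold higher number from compound 3 to compound 4 (0.92 log units; beyond the scatter) is beyond the scatter and means that more compound is needed once the chloro group is present. With the 4-chlorophenyl group held constant, the nitrogen can now be read at three points, since a 14-fold higher number from compound 1 to compound 4 (1.15 log units; beyond the scatter) and a 5.7-fold lower number from compound 2 to compound 4 (0.76 log units; beyond the scatter) place ethoxycarbonyl in an intermediate position, with more compound needed than with hydrogen and less than with butylcarbamoyl. The earlier single step on this nitrogen therefore resolves into two parts, both beyond the scatter, though the compounds shown offer no measured explanation for either part or for the chloro step.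

On these data alone, whether chloro has a similar effect with a free amine or a butyl urea on the nitrogen remains open, as neither compound 1 nor compound 2 has a partner carrying an unsubstituted phenyl group. Also open, as far as these compounds go, is whether fluoro or methoxy at the same place, or a longer chain in place of the ethoxy group, would move the number in the same direction.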